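The source may hold more compounds than are shown below. What is called first, only, known or untested is meant among the compounds shown, and "the series" means these compounds.

The measured compounds:
Compound 1 `C#CCOc1ccc2c(=O)c(-c3cc(OC)c(OC)cc3OC)coc2c1` gives > 10000 nM in a functional assay on HUVEC cells (Homo sapiens) for antiproliferative activity, read by MTT assay, with a stated time of 24 h; a higher number here means a weaker inhibitor, a lower number a stronger inhibitor; this is a limit of the assay, not a number.
Compound 2 `COc1cccc(C(=O)Oc2ccc3c(=O)c(-c4cc(OC)c(OC)cc4OC)coc3c2)c1` gives > 10000 nM in this assay, again a limit rather than a number.
Compound 3 `COc1cc(OC)c(-c2coc3cc(OCc4ccccc4C(F)(F)F)ccc3c2=O)cc1OC` gives > 10000 nM in this assay, also a limit.

Among the compounds with values here, compound 2 thus stands only at a limit, and the two other values shown are limits as well, so no compound can be placed above or below another on these numbers. Compound 4 `COc1cc(OC)c(-c2coc3cc(OCc4ccccc4C#N)ccc3c2=O)cc1OC` is the compound still to be measured. It differs from compound 2 as follows: 2-cyanobenzyl in place of (3-methoxyphenyl)carbonyl on an oxygen on an aromatic ring. The measured steps that touch compound 2 are a step that the two limits leave unreadable from compound 1 to compound 2 and a step that the two limits leave unreadable from compound 2 to compound 3; the remaining measured step is a step that the two limits leave unreadable from compound 1 to compound 3. None of the three has a readable size because of the limit of > 10000 nM in this assay, at which 3 of the 3 values shown sit. Compound 3 carries a 2-(trifluoromethyl)benzyl group on the same oxygen and sits at the limit, which is the nearest guide to compound 4. The step from compound 2 to compound 4 in this assay is therefore expected to be a step that the limit leaves unreadable from compound 2 to compound 4, with no direction that the data allow to be read. Compound 4 is estimated to give 15000 nM, within 4000 nM to 60000 nM, and most probably will again be reported only as a limit.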

Compound 4, half-maximal inhibitory concentration: > 10000 nM
Compound 4 ended at the assay's limit (the forecaster's own chance of this, stated with the estimate: 80%); the middle value is on the limit's open side.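

In this assay compound 4 gives > 10000 nM, which is a limit and not a number. No step between compound 4 and compound 1, compound 2 or compound 3 can be read, because all of them sit at the same limit: the limit of > 10000 nM in this assay, at which 4 of the 4 values shown sit.

The compounds shown leave open which group on the oxygen, if any, would give a readable value in this assay.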